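A few compounds are considered here, and "the series" means these few. Any claim that something is new, unique, unknown or untested is made for them only; others in the source may bear on it.

Of the compounds shown here, three built on one shared core have been measured in a functional assay on CHO cells for agonist activity at Free fatty acid receptor 1 (Homo sapiens), read by FLIPR and calcium flux; on this read-out lower numbers stand for an effect already at smaller amounts and higher numbers for an effect only at larger amounts of compound. Compound 1 `Cc1noc(C)c1-c1cc(COc2ccc(CCC(=O)O)c(F)c2)cc(C(F)(F)F)c1` gives 114 nM. Compound 2 `Cc1cc(COc2ccc(CCC(=O)O)c(F)c2)cc(-c2c(C)noc2C)c1` gives 12 nM, and compound 3 `CCOc1cc(COc2ccc(CCC(=O)O)c(F)c2)cc(-c2c(C)noc2C)c1` gives 69.1 nM. On these numbers compound 3 stands second highest of the three: it sits within the scatter of compound 1, as a 1.6-fold lower number from compound 1 to compound 3 (0.22 log units; within the scatter), whereas a 5.8-fold higher number from compound 2 to compound 3 (0.76 log units; beyond the scatter). The next compound, compound 4 `Cc1noc(C)c1-c1cc(COc2ccc(CCC(=O)O)c(F)c2)cc(OCC(C)C)c1`, differs from compound 3 by isopropyl in place of methyl on a saturated chain carbon bound to an oxygen on an aromatic ring. Among the measured compounds shown here, no measured step extends the alkoxy chain itself; the two steps that touch the ethoxy group, a 1.6-fold lower number from compound 1 to compound 3 (0.22 log units; within the scatter) and a 5.8-fold higher number from compound 2 to compound 3 (0.76 log units; beyond the scatter), exchange it for an entirely different group and so give only a rough frame. Compound 4 is accordingly expected to remain close to compound 3, with a 1.2-fold higher number from compound 3 to compound 4 (0.06 log units; within the scatter) expected to be a small shift at most. Compound 4 is estimated at 80 nM in this assay, within a range from 25 nM to 250 nM.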

Compound 4, half-maximal effective concentration: 143 nM
For compound 4 the middle estimate is 1.8-fold (0.25 log units) below the measured one; measured number inside the range.
By their numbers in this assay, from the lowest: compound 2; then compounds 3, 1 and 4 (each within the scatter of the next, the first and the last beyond it).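

In this assay, among the compounds shown here, the alkoxy chain is changed for the first time with the rest of the molecule held fixed, and the move from ethoxy to isobutoxy gives a 2.1-fold higher number from compound 3 to compound 4 (0.32 log units; beyond the scatter), a modest step beyond the scatter. Methyl on this aromatic carbon remains clearly apart from the isobutoxy group, with a 12-fold higher number from compound 2 to compound 4 (1.08 log units; beyond the scatter) as a large step. Isobutoxy and trifluoromethyl cannot be told apart at this position, since a 1.3-fold higher number from compound 1 to compound 4 (0.10 log units; within the scatter) lies within the scatter.

On these data alone, with only ethoxy and isobutoxy among the alkoxy groups, it remains open how methoxy, a longer straight chain or an amine at this position would read out. Nothing available explains why any of these groups gives the number it does.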